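Swapping a Carboxyethenyl Arm for an Aminoethanol Chain

A few compounds are considered here, and "the series" means these few. Any claim that something is new, unique, unknown or untested is made for them only; others in the source may bear on it.

Of the compounds shown here, three of one series have been tested in an ADME assay on HEp-2 cells (Homo sapiens) for cytotoxicity, read by CCK-8 assay, with a stated time of 6 days; a lower number here means that less compound is tolerated, a higher number that more compound is tolerated. Compound 1 `O=c1n(Cc2nc3ccc(F)cn3c2CCCCO)c2cnccc2n1C1CC1` carries fluoro on an aromatic carbon, and compound 2 `O=c1n(Cc2nc3ccc(C(F)(F)F)cn3c2CCCCO)c2cnccc2n1C1CC1` differs from it by trifluoromethyl in place of fluoro on that aromatic carbon. Compound 3 `O=C(O)/C=C/c1c(Cn2c(=O)n(C3CC3)c3ccncc32)nc2cc(Cl)ccn12` carries a 2-carboxyethenyl arm on its core. In this assay compound 1 gives > 100000 nM, which is a limit of the assay rather than a number. Compound 2 gives > 100000 nM, again only a limit. Compound 3 gives > 100000 nM, also a limit. Compound 3 therefore stands level with the other two at the edge of what the assay can read, and the step that the two limits leave unreadable from compound 1 to compound 2 cannot be sized.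

Compound 4 `O=c1n(Cc2nc3cc(Cl)ccn3c2CNCCO)c2cnccc2n1C1CC1` differs from compound 3 by ((2-hydroxyethyl)amino)methyl in place of 2-carboxyethenyl on an aromatic carbon. Among the compounds with values here, no measured step mirrors this change, and the only measured step, a step that the two limits leave unreadable from compound 1 to compound 2, is unreadable. All three values shown sit at one point, (the limit of > 100000 nM in this assay, at which 3 of the 3 values shown sit), so compound 4 is expected to show no step beyond the scatter, that is a number no higher from compound 3 to compound 4 (the limit leaves the size open). Compound 4 is accordingly estimated at 100000 nM, with a range from 50000 nM to 200000 nM, most likely reported once more as a limit.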

Compound 4, half-maximal cytotoxic concentration: > 100000 nM
Compound 4 was reported as a limit; the forecaster's own chance of this, stated with the estimate: 80%; the middle value lies on the limit itself.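

No new step can be read from compound 3 to compound 4, since in this assay each gives only a limit, as does every compound in the series: the limit of > 100000 nM in this assay, at which 4 of the 4 values shown sit.

The compounds shown leave open how much of any of them the cells tolerate, and whether ((2-hydroxyethyl)amino)methyl in place of 2-carboxyethenyl changes that tolerance at all.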